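This account rests on a few compounds, and the source may have more. Where it says the series, first, only, none or still open, it means among the compounds named here.

Compound 1 `Cc1nc(N)c2c(-c3cccs3)cn([C@@H]3O[C@H](CO)[C@@H](O)[C@H]3O)c2n1` is tested in an ADME assay on BJ cells (Homo sapiens), read by MTT assay, with a stated time of 72 h (a higher number here means a weaker inhibitor, a lower number a stronger inhibitor), and reaches only a limit of the assay at > 100000 nM. Compound 3 `C#Cc1cn([C@@H]2O[C@H](CO)[C@@H](O)[C@H]2O)c2nc(C)nc(N)c12`, which differs from it by ethynyl in place of thiophen-2-yl on an aromatic carbon, likewise gives a limit in this assay at > 100000 nM. The step that the two limits leave unreadable from compound 1 to compound 3 therefore cannot be read, since both values sit at the limit of > 100000 nM in this assay, at which 2 of the 3 values shown sit. Among the compounds with values here, compound 2 `COc1nc(N)nc2c1c(-c1cccs1)cn2[C@@H]1O[C@H](CO)[C@@H](O)[C@H]1O` gives in this assay the single number in this set, 99900 nM. How the core of compound 2 differs from that of compound 1 is not broken down here. Compound 4 `C#Cc1cn([C@@H]2O[C@H](CO)[C@@H](O)[C@H]2O)c2nc(N)nc(OC)c12` carries the same change, (ethynyl in place of thiophen-2-yl on an aromatic carbon), and has not yet been measured. From compound 2 the step of a 1.0-fold higher number from compound 2 to compound 4 (0.00 log units; within the scatter) is expected to be small, because compound 1 and compound 3 both sit at the limit of > 100000 nM in this assay, at which 2 of the 3 values shown sit, and compound 2 gives 99900 nM. Compound 4 is estimated to give 100000 nM in this assay, with a range from 40000 nM to 250000 nM.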

Compound 4, half-maximal inhibitory concentration: > 100000 nM
Compound 4 gave a limit, no number; the forecaster's own chance of this, stated with the estimate: 60%; the middle value lies on the limit itself.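

In this assay compound 4 gives > 100000 nM, which is a limit of the assay and not a number. On the core of compound 2, ethynyl in place of thiophen-2-yl on an aromatic carbon gives a number no lower from compound 2 to compound 4 (the limit leaves the size open). This shows that the change brings no lower number on either core, but neither step can be read in size, so it does not show that the change has the same size on both cores, because the values gather at one end of the assay: the limit of > 100000 nM in this assay, at which 3 of the 4 values shown sit.

Only thiophen-2-yl and ethynyl are shown at this place. From the compounds shown here alone, whether an amine, a carboxylic acid or a longer chain on this aromatic carbon would give a readable number in this assay stays open.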